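Triazole aryl exchange in the spiro series: compound 4

The source may hold more compounds than are shown below. What is called first, only, known or untested is meant among the compounds shown, and "the series" means these compounds.

Compound 1 `N#CC1=C(N)Oc2c(c3nc4ccccc4nc3c3ccccc23)C12C(=O)N(Cc1cnnn1-c1ccccc1Br)c1ccccc12`: > 50000 nM
Compound 2 `N#CC1=C(N)Oc2c(c3nc4ccccc4nc3c3ccccc23)C12C(=O)N(Cc1cnnn1-c1ccc(S(N)(=O)=O)cc1)c1ccccc12`: 31200 nM
Compound 3 `N#CC1=C(N)Oc2c(c3nc4ccccc4nc3c3ccccc23)C12C(=O)N(Cc1cnnn1-c1cccc(S(N)(=O)=O)c1)c1ccccc12`: 11300 nM

In a functional assay on HCT-116 cells (Homo sapiens) for antiproliferative activity, read by MTT assay, with a stated time of 48 h (a lower number here means a stronger inhibitor, a higher number a weaker inhibitor), compound 3 gives 11300 nM, the lowest of the two numbers shown. Compound 2 gives 31200 nM. For compound 1 the assay reports only a limit, > 50000 nM, as shown by the limit of > 50000 nM in this assay, at which 1 of the 3 values shown sits. The measured steps are a 2.8-fold lower number from compound 2 to compound 3 (0.44 log units; beyond the scatter), an at least 4.4-fold lower number from compound 1 to compound 3 (0.64 log units; beyond the scatter) and an at least 1.6-fold lower number from compound 1 to compound 2 (0.20 log units; that floor lies within the scatter); the first two lie beyond the scatter, the last sits at a floor within it.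

Compound 4 `N#CC1=C(N)Oc2c(c3nc4ccccc4nc3c3ccccc23)C12C(=O)N(Cc1cnnn1-c1ccc(F)c(Cl)c1)c1ccccc12` differs from compound 3 by 3-chloro-4-fluorophenyl in place of 3-sulfamoylphenyl on an aromatic nitrogen. For the measured compounds named here, no measured step covers this exchange. What bears on it is the direction of the sulfamoyl steps: compound 1, which carries a halogen-bearing phenyl without a sulfamoyl group, gives only a limit, and an at least 4.4-fold lower number from compound 1 to compound 3 (0.64 log units; beyond the scatter) records the gain on moving to 3-sulfamoylphenyl. Compound 4 removes the sulfamoyl group and brings in two halogens, so the step is expected to run back toward the limit; a higher number, a 3.1-fold higher number from compound 3 to compound 4 (0.49 log units; beyond the scatter), is estimated. For compound 4 the expected value in this assay is 35000 nM, within 10000 nM to 100000 nM, with a fair chance that only a limit is reported.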

Compound 4, half-maximal inhibitory concentration: > 50000 nM
Compound 4: a limit, no number; the forecaster's own chance of this, stated with the estimate: 40%; at least 1.4-fold (0.15 log units) between middle value and limit.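

In this assay compound 4 gives > 50000 nM, which is a limit and not a number.

Replacing the sulfamoyl-bearing phenyl on the aromatic nitrogen gives an at least 4.4-fold higher number from compound 3 to compound 4 (0.64 log units; beyond the scatter), which lies beyond the scatter, and an at least 1.6-fold higher number from compound 2 to compound 4 (0.20 log units; that floor lies within the scatter), whose floor lies within it; the step between compound 1 and compound 4 cannot be read, as both values are limits. Compound 4 now joins compound 1, so 3-chloro-4-fluorophenyl and 2-bromophenyl both end at a limit, while only the sulfamoyl-bearing compound 2 and compound 3 return numbers, a split that no compound shown goes against and that now spans two different halogen patterns at this position: the limit of > 50000 nM in this assay, at which 2 of the 4 values shown sit.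

Still open, from the compounds shown here alone, is whether a number in this assay depends on the sulfamoyl group itself, or whether a carboxylic acid or an amine on the same phenyl would also return one. Also open, going by these compounds, is how an unsubstituted phenyl would read at this position, which would separate any contribution of the halogens from the absence of the sulfamoyl group.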